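The source may hold more compounds than are shown below. What is called first, only, known or untested is meant among the compounds shown, and "the series" means these compounds.

Compound 1 `Cc1cc(-c2ccccc2)n(/C(N)=N/S(=O)(=O)c2cc(C)c(Cl)cc2SCc2ccccc2C(F)(F)F)n1` gives 0.306 h in an ADME assay on microsomes from liver (Homo sapiens) for metabolic stability, read by LC-MS, using NADPH, tested at 5 uM; on this read-out higher numbers stand for a longer-lived compound and lower numbers for a shorter-lived compound.
Compound 2 `Cc1cc(S(=O)(=O)/N=C(\N)n2nccc2-c2ccccc2)c(SCc2cccc(Cl)c2)cc1Cl` gives 0.309 h in this assay.
Compound 3 `Cc1cc(S(=O)(=O)/N=C(\N)n2nccc2-c2ccccc2)c(SCc2cccc3ccccc23)cc1Cl` gives 0.268 h in this assay.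

Compound 3 has the lowest of the three numbers, but its gap to compound 1 and to compound 2 is within the scatter, so no order among them can be read. Among the compounds with values here, the only measured step is a 1.2-fold lower number from compound 2 to compound 3 (0.06 log units; within the scatter), which also stays within the scatter. Compound 4 `Cc1cc(S(=O)(=O)/N=C(\N)n2nccc2-c2ccccc2)c(SCc2ccccc2C(F)(F)F)cc1Cl` differs from compound 3 as follows: 2-(trifluoromethyl)phenyl in place of naphthalen-1-yl on a saturated chain carbon bound to a sulfur. Compound 1 carries the same 2-(trifluoromethyl)benzyl group on another core and sits with the rest. Compound 4 is therefore expected to show no step beyond the scatter, a 1.1-fold higher number from compound 3 to compound 4 (0.03 log units; within the scatter), with an estimated value of 0.29 h in this assay, ranging from 0.15 h to 0.6 h.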

Compound 4, half-life: 0.15 h
Estimate against measurement, compound 4: 1.9-fold (0.29 log units) above; the measured number falls inside the stated range.
By their numbers in this assay, from the lowest: compounds 4, 3, 1 and 2 (each within the scatter of the next, the first and the last beyond it).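

Within the data shown here, with 2-(trifluoromethyl)phenyl on a saturated chain carbon bound to a sulfur, this assay gives the first steps beyond the scatter: replacing 3-chlorophenyl gives a 2.1-fold lower number from compound 2 to compound 4 (0.31 log units; beyond the scatter), whereas replacing naphthalen-1-yl gives a 1.8-fold lower number from compound 3 to compound 4 (0.25 log units; within the scatter). With that group held, hydrogen in place of methyl on an aromatic carbon also counts, giving a 2.0-fold lower number from compound 1 to compound 4 (0.31 log units; beyond the scatter). No measurement here accounts for these shorter half-lives.

The compounds shown leave open whether an amine or a carboxylic acid at this place would lengthen the half-life. Among these compounds, they also show the hydrogen-for-methyl change with only this one group.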